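The compounds below may be only part of what the source reports. "The series", "measured", "known", "first", "only" and "open" are said of these compounds alone.

Measured in a functional assay on HBL-100 cells (Homo sapiens) for antiproliferative activity, read by sulforhodamine B assay, with a stated time of 48 h (on this read-out lower numbers stand for stronger inhibition of growth and higher numbers for weaker inhibition of growth), so far:
- compound 1 `CCCCCCC(C#CC(=O)OC)O/C=C/C(=O)OC` gives 2500 nM
- compound 2 `COC(=O)C#CC(O/C=C/C(=O)OC)C(C)(C)C` gives 1800 nM
- compound 3 `COC(=O)C#CC(O/C=C/C(=O)OC)C1CC1` gives 250 nM

Compound 3 has the lowest number of the three, and both steps to it lie beyond the scatter (a 10-fold lower number from compound 1 to compound 3 (1.00 log units; beyond the scatter)) and (a 7.2-fold lower number from compound 2 to compound 3 (0.86 log units; beyond the scatter)). The two compounds without a ring on this carbon do not separate beyond the scatter (a 1.4-fold lower number from compound 1 to compound 2 (0.14 log units; within the scatter)).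

Compound 4 `COC(=O)C#CC(O/C=C/C(=O)OC)C(C)C` is the next case (isopropyl in place of cyclopropyl on a saturated chain carbon bound to an oxygen on an unsaturated carbon and a triple-bonded carbon). Going by the values given here, no measured step makes this exchange directly. The closest evidence is the pair of steps above, and the smaller one is the more cautious guide (a 7.2-fold lower number from compound 2 to compound 3 (0.86 log units; beyond the scatter)). Compound 4 also lacks the ring, so a step to a higher number in this assay is expected, of modest size and probably beyond the scatter. Among the compounds with values here, with only three compounds behind it, this expectation is loose.

The expected move is (a 3.2-fold higher number from compound 3 to compound 4 (0.51 log units; beyond the scatter)). For compound 4 the estimate is 800 nM with an expected range from 300 nM to 2200 nM as its limits.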

Compound 4, concentration for 50% growth inhibition: 450 nM
Estimate against measurement, compound 4: 1.8-fold (0.25 log units) above, and the stated range covers the measured number.
By their numbers in this assay, from the lowest: compounds 3 and 4 (each within the scatter of the next); then compounds 2 and 1 (each within the scatter of the next).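

In this assay the ring on this carbon does not set compound 3 apart, since isopropyl in place of cyclopropyl gives a 1.8-fold higher number from compound 3 to compound 4 (0.26 log units; within the scatter) and so a group with no ring can reach the same range. The open-chain groups do separate: hydrogen in place of methyl on a saturated chain carbon bound to three saturated chain carbons gives a 4.0-fold lower number from compound 2 to compound 4 (0.60 log units; beyond the scatter) while isopropyl in place of hexyl gives a 5.6-fold lower number from compound 1 to compound 4 (0.74 log units; beyond the scatter) and so the choice of group at this position matters even without a ring. No measurement at hand accounts for these differences.

From the compounds shown here alone, all four groups on this carbon are built of carbon only, so it stays open how an amine, a carboxylic acid or a methoxymethyl chain would behave here. Going by these compounds, whether these steps hold on any other cell line also stays open.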